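Replacing 4-methoxyphenyl with 3-bromophenyl: working notes

The source may hold more compounds than are shown below. What is called first, only, known or untested is meant among the compounds shown, and "the series" means these compounds.

Compound 1 `CCCc1ccc(NC(=O)C2CCN(C/C=C/c3ccccc3)CC2)cc1`: 9410 nM
Compound 2 `CCCCc1ccc(NC(=O)C2CCN(C/C=C/c3ccccc3)CC2)cc1`: 4320 nM
Compound 3 `COc1ccc(NC(=O)C2CCN(C/C=C/c3ccccc3)CC2)cc1`: 88800 nM

In a functional assay on HepG2 cells (Homo sapiens) for inhibition, read by MTT assay, with a stated time of 72 h (a higher number here means a weaker inhibitor, a lower number a stronger inhibitor), compound 3 carries the highest number of the three and is the weakest. Compound 4 `O=C(Nc1cccc(Br)c1)C1CCN(C/C=C/c2ccccc2)CC1` has 3-bromophenyl in place of 4-methoxyphenyl on an amide-type nitrogen. Among the measured compounds shown here, no measured step covers bromine or a shift of substituent position. The nearest evidence is the replacement of alkyl by methoxy, with a 9.4-fold higher number from compound 1 to compound 3 (0.97 log units; beyond the scatter) and a 21-fold higher number from compound 2 to compound 3 (1.31 log units; beyond the scatter), while chain extension gave only a 2.2-fold lower number from compound 1 to compound 2 (0.34 log units; beyond the scatter). Leaving the methoxy compound may therefore recover some strength, so a modest step to a lower number is expected in this assay. The expected change is a 4.4-fold lower number from compound 3 to compound 4 (0.65 log units; beyond the scatter). For compound 4 the estimated value is 20000 nM, with an expected range from 6000 nM to 70000 nM.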

Compound 4, half-maximal inhibitory concentration: 19200 nM
Compound 4: middle estimate off by 1.0-fold (0.02 log units), on the high side; the range from low to high includes it.
By their numbers in this assay, from the lowest: compound 2; then compound 1; then compound 4; then compound 3.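

In this assay, 3-bromophenyl in place of 4-methoxyphenyl on the amide-type nitrogen gives a 4.6-fold lower number from compound 3 to compound 4 (0.67 log units; beyond the scatter), so a group without an alkyl chain can also improve on the methoxy compound. That recovery is incomplete against the propyl analogue, with a 2.0-fold higher number from compound 1 to compound 4 (0.31 log units; beyond the scatter). No available evidence accounts for either step.

The compounds shown do not separate the contribution of bromine from that of its placement on the ring. Going by these compounds, how chlorine, a nitrile or an amine would compare at this ring remains open.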